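Methoxy count on the aryl ring and growth inhibition

The source may hold more compounds than are shown below. What is called first, only, known or untested is meant among the compounds shown, and "the series" means these compounds.

Going by the values given here, compound 2 `COc1cc(-c2cc(/C=C/C(=O)c3ccc(N)cc3)[nH]n2)cc(OC)c1OC` sits at the lower of the two numbers measured so far: in a functional assay on OVCAR-8 cells (Homo sapiens) for inhibition, read by sulforhodamine B assay, with a stated time of 48 h (a lower number here means a stronger inhibitor of growth, a higher number a weaker inhibitor of growth), compound 2 gives 9760 nM. Its nearest neighbour, compound 1 `COc1ccc(-c2cc(/C=C/C(=O)c3ccc(N)cc3)[nH]n2)cc1`, gives 15400 nM in this assay; the two values lie within the scatter of each other, so no order between them can be read. Compound 3 `COc1ccc(-c2cc(/C=C/C(=O)c3ccc(N)cc3)[nH]n2)cc1OC` has not been measured. It differs from compound 2 by hydrogen in place of methoxy on an aromatic carbon. Among the compounds with values here, no step between measured compounds covers this change; the only comparison available, compound 1 against compound 2, involves two methoxy groups and shows nothing beyond the scatter. A step of no size beyond the scatter is therefore expected, a 1.2-fold higher number from compound 2 to compound 3 (0.09 log units; within the scatter). For compound 3 the estimate in this assay is 12000 nM, with a range from 5000 nM to 30000 nM.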

Compound 3, concentration for total growth inhibition: 10500 nM
For compound 3 the middle estimate is 1.1-fold (0.06 log units) above the measured one; the measured number falls inside the stated range.
By their numbers in this assay, from the lowest: compounds 2, 3 and 1 (each within the scatter of the next).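

Single-position steps on the methoxy pattern now exist. In this assay, hydrogen in place of methoxy on an aromatic carbon, ortho to a methoxy group and meta to a large group, gives a 1.1-fold higher number from compound 2 to compound 3 (0.03 log units; within the scatter), while methoxy in place of hydrogen on an aromatic carbon gives a 1.5-fold lower number from compound 1 to compound 3 (0.17 log units; within the scatter). Both steps lie within the scatter, so neither single change separates these compounds, and no order can be read among compound 1, compound 2 and compound 3. No measured data on hand bear on these results.

The compounds shown exchange only methoxy and hydrogen, leaving open what a hydroxyl group, a chlorine atom or a longer chain such as ethoxy would do at this position. Also open, as far as these compounds go, is whether replacing the amine of the shared core with an amide would move the number beyond the scatter.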